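Tert-butyl for benzyl on the nitrone nitrogen

This account rests on a few compounds, and the source may have more. Where it says the series, first, only, none or still open, it means among the compounds named here.

Three triazole nitrones have been tested in a functional assay on MDA-MB-231 cells (Homo sapiens) for inhibition, read by MTT assay, with a stated time of 24 h; a lower number here means a stronger inhibitor, a higher number a weaker inhibitor. Compound 1 `COc1ccc(-n2cc(/C=[N+](\[O-])Cc3ccccc3)nn2)cc1` carries a benzyl group on the double-bonded nitrogen; in this assay compound 1 gives only a limit, > 100000 nM. Compound 2 `[O-]/[N+](=C\c1cn(CCC(F)(F)C(F)(F)C(F)(F)C(F)(F)C(F)(F)C(F)(F)F)nn1)Cc1ccccc1` shares the nitrone but bears a different group on the triazole; the difference between the two cores is not broken down here. In this assay compound 2 likewise gives only a limit, > 100000 nM. Compound 3 `COc1ccc(-n2cc(/C=[N+](\[O-])C(C)(C)C)nn2)cc1` is compound 1 with tert-butyl in place of benzyl on a double-bonded nitrogen, and in this assay compound 3 gives 23100 nM. The step is an at least 4.3-fold lower number from compound 1 to compound 3 (0.63 log units; beyond the scatter), measured against (the limit of > 100000 nM in this assay, at which 2 of the 3 values shown sit).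

Compound 4 `CC(C)(C)/[N+]([O-])=C/c1cn(CCC(F)(F)C(F)(F)C(F)(F)C(F)(F)C(F)(F)C(F)(F)F)nn1` applies the same change to compound 2, namely (tert-butyl in place of benzyl on a double-bonded nitrogen). The surroundings of the place are the same in both pairs. By analogy with the step from compound 1 to compound 3, a step of an at least 2.5-fold lower number from compound 2 to compound 4 (0.39 log units; beyond the scatter) is expected, though a limit is again possible given (the limit of > 100000 nM in this assay, at which 2 of the 3 values shown sit). Compound 4 is therefore estimated at 40000 nM, between 10000 nM and 200000 nM.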

Compound 4, half-maximal inhibitory concentration: 9800 nM
The estimate for compound 4 lay 4.1-fold (0.61 log units) above the measured number; measured number below the stated range.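

In this assay, tert-butyl in place of benzyl on the double-bonded nitrogen goes with a lower number on the second core as well, with an at least 10-fold lower number from compound 2 to compound 4 (1.00 log units; beyond the scatter). The direction of the change therefore carries from one core to the other in both pairs shown, and neither pair goes against it, but nothing can be said about whether its size carries over: the same change on two cores in this assay, an at least 4.3-fold lower number (0.63 log units; beyond the scatter) from compound 1 to compound 3 and an at least 10-fold lower number (1.00 log units; beyond the scatter) from compound 2 to compound 4; the limit leaves it open whether they differ Both benzyl compounds stand at a limit and not at a number, so neither step has a known full size, and two cores set no rule for any further core: the limit of > 100000 nM in this assay, at which 2 of the 4 values shown sit.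

The compounds shown leave open whether other groups on the double-bonded nitrogen, such as isopropyl or cyclohexyl, would go with numbers like those of the tert-butyl compounds or with the limit of the benzyl compounds. They also leave open how the same change would read on a core carrying an amine or a carboxylic acid in place of the groups that set these two cores apart.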